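This account rests on a few compounds, and the source may have more. Where it says the series, first, only, none or still open, it means among the compounds named here.

Measured values in a functional assay on HCT-116 cells (Homo sapiens) for antiproliferative activity, read by MTT assay, with a stated time of 72 h; a higher number here means a weaker inhibitor, a lower number a stronger inhibitor:

- Compound 1 `O=C(CCc1cccc2c1B(O)OC2)Nc1cccc(I)c1` gives 2300 nM
- Compound 2 `O=C(CCc1cccc2c1B(O)OC2)Nc1cccc(-c2ccccc2)c1` gives 890 nM
- Compound 3 `O=C(CCc1cccc2c1B(O)OC2)Nc1cccc(-c2ccc(F)cc2)c1` gives 550 nM

Compound 3 and compound 2 cannot be told apart on these numbers, while compound 1 lies clearly higher than both. Compound 4 `COc1ccc(-c2cccc(NC(=O)CCc3cccc4c3B(O)OC4)c2)cc1` differs from compound 3 in one group (methoxy in place of fluoro on an aromatic carbon): methoxy in place of fluoro on an aromatic carbon, para to a large group. The closest guide is fluoro in place of hydrogen at that place (a 1.6-fold lower number from compound 2 to compound 3 (0.21 log units; within the scatter)). The larger steps (a 2.6-fold lower number from compound 1 to compound 2 (0.41 log units; beyond the scatter)) and (a 4.2-fold lower number from compound 1 to compound 3 (0.62 log units; beyond the scatter)) replace iodo instead, so they bear on this change only weakly. In this assay no step beyond the scatter is therefore expected, in either direction. The estimated change is small (a 1.2-fold higher number from compound 3 to compound 4 (0.07 log units; within the scatter)). Compound 4 is expected at 650 nM (estimated range 280 nM to 1500 nM).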

Compound 4, half-maximal inhibitory concentration: 160 nM
Compound 4: the middle estimate sits 4.1-fold (0.61 log units) above what was measured; the measured number lies below the stated range.
By their numbers in this assay, from the lowest: compound 4; then compounds 3 and 2 (each within the scatter of the next); then compound 1.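

The group on this aromatic carbon matters more than the fluoro in place of hydrogen step suggested: in this assay, methoxy in place of fluoro gives a 3.4-fold lower number from compound 3 to compound 4 (0.54 log units; beyond the scatter), and methoxy in place of hydrogen gives a 5.6-fold lower number from compound 2 to compound 4 (0.75 log units; beyond the scatter). Replacing iodo with 4-methoxyphenyl gives a 14-fold lower number from compound 1 to compound 4 (1.16 log units; beyond the scatter), the largest step in this set. No measurement at hand explains why methoxy has this effect.

As far as these compounds go, it remains open whether this gain is specific to methoxy or would also appear with a hydroxy, an ethoxy or an amine at this place.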